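This account rests on a few compounds, and the source may have more. Where it says the series, first, only, none or still open, it means among the compounds named here.

Compound 1 `COc1ccc(-c2cnc3nc(N)nc(N4CCCCC4)c3n2)cc1` is tested in an assay on cerebellum for inhibition of Nitric oxide synthase 3 (Sus scrofa) (a higher number here means a weaker inhibitor, a lower number a stronger inhibitor), where compound 1 gives 50000 nM. Among the three numbers here, compound 1 stands second highest: compound 2 `Nc1nc(N2CCCCC2)c2nc(-c3ccccc3)cnc2n1` gives 62000 nM, and compound 3 `Nc1nc(N)c2c(n1)NCC(c1ccccc1)N2` gives 6000 nM, which is the furthest from compound 1. Among the compounds with values here, the only step between measured compounds is a 1.2-fold higher number from compound 1 to compound 2 (0.09 log units; within the scatter). Compound 4 `COc1ccc(-c2cnc3nc(N)nc(N(C)C)c3n2)cc1` differs from compound 1 by dimethylamino in place of piperidin-1-yl on an aromatic carbon. Within the data shown here, no measured step touches this part of the shared core, so nothing here shows how such a change moves this assay. With no evidence for a shift in either direction, the number for compound 4 is expected to stay close to that of compound 1; the estimated step is no change at the digits printed from compound 1 to compound 4 (within the scatter). Compound 4 is therefore estimated at 50000 nM, with a range from 20000 nM to 125000 nM.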

Compound 4, half-maximal inhibitory concentration: 74000 nM
Estimate against measurement, compound 4: 1.5-fold (0.17 log units) below, within the range that was stated.
By their numbers in this assay, from the lowest: compound 3; then compounds 1, 2 and 4 (each within the scatter of the next).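

In this assay, dimethylamino in place of piperidin-1-yl on this aromatic carbon gives a 1.5-fold higher number from compound 1 to compound 4 (0.17 log units; within the scatter) and so stays within the scatter. At this position, then, the six-membered non-aromatic ring can give way to a group with no ring, and the smaller group leaves no readable change in the number. Nothing measured here explains this result.

As far as these compounds go, whether a plain amino group, a morpholine ring or a longer chain such as dibutylamino at this carbon would also leave the number unchanged remains open.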